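The source may report more compounds than this note shows. Statements on the series, on what has been measured and on what is new or still open speak of the compounds shown alone.

In an in vitro functional assay on 1321-N1 cells for antagonist activity at transient receptor potential cation channel subfamily V member 1 (Homo sapiens), read by FLIPR and calcium flux (on this read-out higher numbers stand for higher potency (the scale is a negative logarithm) and lower numbers for lower potency), compound 2 `Cc1nc(-c2ccc(F)cc2)ccc1C(=O)Nc1ccc2scnc2c1` gives 7.5, the highest of the two numbers in hand; compound 1 `Cc1nc2ccc(NC(=O)c3ccc(-c4ccc(F)cc4)nc3C)cc2[nH]1` gives 6, a gap beyond the scatter. Compound 3 `Cc1nc(-c2ccc(F)cc2)ccc1C(=O)Nc1ccc2sc(N(C)C)nc2c1` is not yet measured and differs from compound 2 by dimethylamino in place of hydrogen on an aromatic carbon. Among the compounds with values here, no measured pair shows this change, so its size cannot be read from the data. The step from compound 2 to compound 3 is expected to be modest, a number 0.30 log units higher from compound 2 to compound 3 (within the scatter), with a gain somewhat more likely than a loss. For compound 3 the estimate in this assay is 7.8, within 6.9 to 8.6.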

Compound 3, negative logarithm of the antagonist equilibrium constant: < 5.8
Compound 3 was reported as a limit; the forecaster's own chance of this, stated with the estimate: 5%; middle value at least 2.00 log units away from the limit.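

In this assay, within the data shown here, dimethylamino in place of hydrogen on the aromatic carbon next to the ring nitrogen and next to the ring sulfur gives a number at least 1.70 log units lower from compound 2 to compound 3 (beyond the scatter) and is the first change read at this position. As far as these compounds go, compound 3 carries a limit and not a number, and the full size of the step stays unknown: the limit of < 5.8 in this assay, at which 1 of the 3 values shown sits.

From the compounds shown here alone, whether the loss is specific to dimethylamino stays open. A methyl group, an unsubstituted amino group or a methoxy group on this carbon would show whether any group other than hydrogen comes close to compound 2 at 7.5 in this assay.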